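Estimating compound 4 from three measured pyrimidine analogues

A few compounds are considered here, and "the series" means these few. Any claim that something is new, unique, unknown or untested is made for them only; others in the source may bear on it.

Measured compounds:
- compound 1, `CCc1nc(NC(CC)CC)c(Cl)nc1-c1ccc(Cl)cc1Cl`: in an assay on IMR-32 cells for displacement of a labelled ligand from corticotropin-releasing factor receptor 1 (Homo sapiens), read by scintillation counting, with a stated time of 2 h (a higher number here means a weaker inhibitor, a lower number a stronger inhibitor), compound 1 gives 71 nM
- compound 2, `CCc1nc(-c2ccc(Cl)cc2Cl)c(CC)nc1NC(C1CC1)C1CC1`: in this assay compound 2 gives 3.7 nM
- compound 3, `CCc1nc(NC(CC)CC)c(OC)nc1-c1ccc(Cl)cc1Cl`: in this assay compound 3 gives 5.9 nM

Compound 2 has the lowest number of the three. Among the measured compounds shown here, its nearest neighbour is compound 3, and the two lie within the scatter of each other; compound 1 is far from both, and the only single-point step among the measured compounds, a 12-fold lower number from compound 1 to compound 3 (1.08 log units; beyond the scatter), is large.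

Compound 4, `CCCN(CC1CC1)c1nc(CC)c(-c2ccc(Cl)cc2Cl)nc1CC`, differs from compound 2 by one change: (cyclopropylmethyl)(propyl)amino in place of (dicyclopropylmethyl)amino on an aromatic carbon. For the measured compounds named here, none of the measured steps touches this position or this kind of change; the one step known concerns methoxy for chloro elsewhere on the core, so it gives no direct guide. With nothing to anchor the direction, a modest step is expected, leaning toward a somewhat higher number, and the uncertainty is wide. Compound 4 is therefore estimated at 10 nM, within a range of 2 nM to 50 nM, which corresponds to an expected 2.7-fold higher number from compound 2 to compound 4 (0.43 log units; beyond the scatter).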

Compound 4, inhibition constant: 19.2 nM
Estimate against measurement, compound 4: 1.9-fold (0.28 log units) below; the range from low to high includes it.
By their numbers in this assay, from the lowest: compounds 2 and 3 (each within the scatter of the next); then compound 4; then compound 1.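

In this assay, this position on the shared core proves sensitive to the amine substituent: (cyclopropylmethyl)(propyl)amino in place of (dicyclopropylmethyl)amino gives a 5.2-fold higher number from compound 2 to compound 4 (0.72 log units; beyond the scatter), even though the leaving and entering groups have the same count of heavy atoms. Among the compounds shown here, the earlier compounds offered only the methoxy for chloro step, elsewhere on the core, so this is the first reading at this place, and it shows that one three-membered ring and the hydrogen-bond donor can be given up together with a modest rise in the number. Nothing shown here explains the size of this step.

From the compounds shown here alone, whether the step follows the lost ring or the lost donor stays open, as the two change together here. Also open, going by these compounds, is how a dipropylamino group or a morpholine would read at this position.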